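This account rests on a few compounds, and the source may have more. Where it says the series, first, only, none or still open, it means among the compounds named here.

Measured in a functional assay on U-937 cells (Homo sapiens) for inhibition, read by MTT assay, with a stated time of 48 h; a lower number here means a stronger inhibitor, a higher number a weaker inhibitor:
- compound 1 `O=C1Nc2ccc(Br)cc2C1(O)c1c[nH]c2ccccc12`: 19.3 ug/mL
- compound 2 `O=C1Nc2ccc(I)cc2C1(O)c1c[nH]c2ccccc12`: 21.6 ug/mL
- compound 3 `O=C1Nc2ccc(F)cc2C1(O)c1c[nH]c2ccccc12`: 43.7 ug/mL

Compound 2 sits within the scatter of compound 1, as a 1.1-fold higher number from compound 1 to compound 2 (0.05 log units; within the scatter) shows, while the larger gap is a 2.0-fold higher number from compound 2 to compound 3 (0.31 log units; beyond the scatter). Compound 4 `Cc1ccc2c(c1)C(O)(c1c[nH]c3ccccc13)C(=O)N2` has methyl in place of iodo on an aromatic carbon. Among the compounds with values here, no methyl compound has been measured, so only the halogen swaps bear on this change. The largest of them is a 2.3-fold higher number from compound 1 to compound 3 (0.35 log units; beyond the scatter), which is modest. A step no larger than the scatter is therefore expected in this assay, with no firm direction. The expected step is a 1.3-fold higher number from compound 2 to compound 4 (0.11 log units; within the scatter). Compound 4 is estimated at 28 ug/mL, with an expected range of 14 ug/mL to 55 ug/mL.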

Compound 4, half-maximal inhibitory concentration: 83.4 ug/mL
Compound 4: the middle estimate sits 3.0-fold (0.47 log units) below what was measured; the measured number lies above the stated range.
By their numbers in this assay, from the lowest: compounds 1 and 2 (each within the scatter of the next); then compounds 3 and 4 (each within the scatter of the next).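

In this assay methyl on this aromatic carbon parts from iodo and bromo, with a 3.9-fold higher number from compound 2 to compound 4 (0.59 log units; beyond the scatter) and a 4.3-fold higher number from compound 1 to compound 4 (0.64 log units; beyond the scatter) as steps larger than any seen among the halogens. Against fluoro there is only a 1.9-fold higher number from compound 3 to compound 4 (0.28 log units; within the scatter) and no order can be drawn, so methyl and fluoro are not separated at this position. Nothing available accounts for these steps.

From the compounds shown here alone, whether chloro would fall with bromo and iodo stays open. So does where an amine or a carboxylic acid on this carbon would land relative to methyl and the halogens.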